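Hydroxy to methylcarbamoyl on a tricyclic saturated core

A few compounds are considered here, and "the series" means these few. Any claim that something is new, unique, unknown or untested is made for them only; others in the source may bear on it.

Three members of this series have numbers in an ADME assay (Gallus gallus) for cytotoxicity, read by microscopy, with a stated time of 24 h (on this read-out lower numbers stand for higher toxicity in this test and higher numbers for lower toxicity in this test), so far. Compound 1 `OC12CCCC3CC(CCC31)C2`, the parent alcohol, gives 6000000 nM in this assay, the highest of the three numbers shown. Compound 2 `O[C@@H]1C2CCCC3C[C@@H]1CC[C@@H]32`, which carries the hydroxy group on another saturated ring carbon of the shared core, gives 750000 nM, a lower number that lies beyond the scatter. Compound 3 `CCCCCCCCOC(=O)C12CCCC3CC(CCC31)C2`, the octyl ester, gives 490000 nM, the lowest number of the three and also beyond the scatter relative to compound 1. No pair among these three differs in one place only, so no single-change step is available within the measured set.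

Compound 4 `CNC(=O)C12CCCC3CC(CCC31)C2` is not yet measured. It differs from compound 1 by methylcarbamoyl in place of hydroxy on a saturated ring carbon. The change is a replacement on the same carbon of the shared core, and both groups keep one hydrogen-bond donor and one acceptor each. Given that compound 3, with its own replacement of the hydroxy group at this carbon, gives 490000 nM, a step downward is expected for compound 4, of moderate size: a 3.0-fold lower number from compound 1 to compound 4 (0.48 log units; beyond the scatter) is the estimated change. Compound 4 is therefore expected to give about 2000000 nM in this assay, within a range of 500000 nM to 6000000 nM.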

Compound 4, minimum cytotoxic concentration: 750000 nM
The estimate for compound 4 lay 2.7-fold (0.43 log units) above the measured number, within the range that was stated.
By their numbers in this assay, from the lowest: compounds 3, 2 and 4 (each within the scatter of the next); then compound 1.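

In this assay, for the compounds shown here, the first single-place change can now be read, and it comes to an 8.0-fold lower number from compound 1 to compound 4 (0.90 log units; beyond the scatter) for methylcarbamoyl in place of hydroxy on this saturated ring carbon. This modest step, beyond the scatter, shows that this change on this carbon does not keep the number at the level of compound 1, even though the hydrogen-bond donor and acceptor counts printed for the two groups are the same, so those matching counts alone do not hold the read-out here. No measurement is available that would account for the size or direction of this step.

The compounds shown leave open whether the step belongs to the carbonyl-linked nitrogen group as such or simply to the larger group on this carbon; a primary carboxamide, a carboxylic acid, an amine or a longer chain on the amide nitrogen at the same carbon would help to separate these readings. They also leave open whether methylcarbamoyl in place of hydroxy gives a step of similar size at the other ring carbon that carries hydroxy in compound 2.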